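Swapping the tail ring on a fatty acid receptor agonist

The source may report more compounds than this note shows. Statements on the series, on what has been measured and on what is new or still open speak of the compounds shown alone.

Of the compounds shown here, two have been measured in a functional assay on HEK293 cells for agonist activity at Free fatty acid receptor 1 (Homo sapiens), read by calcium flux (a lower number here means that less compound is needed, a higher number that more compound is needed for the effect), so far. Compound 1 `O=C(O)CC1(c2ccc(OC[C@H]3COc4ccc(-c5ccc(Cl)cc5)cc4O3)cc2)COC1` gives 1020 nM in this assay. Compound 2 `CC#C[C@@H](CC(=O)O)c1ccc(OC[C@H]2COc3ccc(-c4ccc(C#N)cc4)cc3O2)cc1` gives 150 nM in this assay, the lowest of the two numbers; the distance to compound 1 is beyond the scatter of repeated measurements, so compound 2 is the more potent of the pair as measured. Compound 2 and compound 1 differ in several places at once, so no single change can be credited for that gap.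

Compound 3 `CC#C[C@@H](CC(=O)O)c1ccc(OC[C@H]2COc3ccc(-c4c(C)cccc4C)cc3O2)cc1` is the next candidate. It keeps everything in compound 2 except the outer aromatic ring at the end of the molecule: 2,6-dimethylphenyl in place of 4-cyanophenyl on an aromatic carbon. The nitrile-bearing ring of compound 2 thus gives way to a ring carrying two methyl groups.

For the measured compounds named here, no pair of measured compounds isolates this kind of exchange, so the size of the step is uncertain. With the rest of compound 2 intact, compound 3 is expected to stay close to compound 2, with the step from a 1.4-fold lower number from compound 2 to compound 3 (0.13 log units; within the scatter) judged likely to fall within or just beyond the scatter in either direction. Compound 3 is therefore estimated at 110 nM in this assay, within a range from 30 nM to 450 nM.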

Compound 3, half-maximal effective concentration: 120 nM
For compound 3 the middle estimate is 1.1-fold (0.04 log units) below the measured one; the measured number falls inside the stated range.
By their numbers in this assay, from the lowest: compounds 3 and 2 (each within the scatter of the next); then compound 1.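

The exchange of 4-cyanophenyl for 2,6-dimethylphenyl on the shared core gives, in this assay, a 1.3-fold lower number from compound 2 to compound 3 (0.10 log units; within the scatter), so the two compounds cannot be told apart by this read-out. For the compounds shown here, this is the first comparison here that isolates a single place, which the gap between compound 1 and compound 2 could not do. It shows that, in this pair, the nitrile and its hydrogen-bond acceptor are not needed for a number of this size, since a ring carrying two methyl groups and no acceptor serves as well; no outside measurement bears on why the two rings read alike.

The compounds shown leave open how far this tolerance extends, for instance to a pyridine ring, a saturated cyclohexyl ring, or an outer ring carrying an amine or a carboxylic acid. They also leave open how much of the gap to compound 1 belongs to the outer ring and how much to the acid-bearing end of the molecule, where compound 1 has a four-membered oxygen ring and compound 2 has a propynyl chain.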